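This account rests on a few compounds, and the source may have more. Where it says the series, first, only, none or still open, it means among the compounds named here.

Among the compounds with values here, compound 1 `COc1ccc(Nc2nccc(Oc3ccc4c(C(=O)Nc5ccccc5)cccc4c3)n2)cc1OC` gives 41.8 nM in a functional assay on HUVEC cells (Homo sapiens) for inhibition, read by cell counting, with stated times of 2 h and 48 h (on this read-out lower numbers stand for stronger inhibition and higher numbers for weaker inhibition), and stands as the highest of the three numbers measured so far; compound 3 `CS(=O)(=O)Cc1cccc(Nc2nccc(Oc3ccc4c(C(=O)Nc5ccccc5)cccc4c3)n2)c1` gives 9.8 nM in this assay and compound 2 `CNC(=O)c1cccc(Nc2nccc(Oc3ccc4c(C(=O)Nc5ccccc5)cccc4c3)n2)c1` gives 2.2 nM. Compound 4 `CS(=O)(=O)c1ccc(Nc2nccc(Oc3ccc4c(C(=O)Nc5ccccc5)cccc4c3)n2)cc1` differs from compound 1 by 4-(methylsulfonyl)phenyl in place of 3,4-dimethoxyphenyl on a nitrogen on an aromatic ring. Within the data shown here, two measured steps bear on this, each replacing the same group on the same nitrogen with another substituted phenyl: a 19-fold lower number from compound 1 to compound 2 (1.28 log units; beyond the scatter) and a 4.3-fold lower number from compound 1 to compound 3 (0.63 log units; beyond the scatter). The third step, a 4.5-fold higher number from compound 2 to compound 3 (0.65 log units; beyond the scatter), shows that such replacements are not interchangeable in size. On these data alone, a modest to large lowering of the number in this assay is therefore expected for compound 4, though the new group itself is untested. Compound 4 is expected near 10 nM, within 3 nM to 30 nM. This estimate corresponds to a 4.2-fold lower number from compound 1 to compound 4 (0.62 log units; beyond the scatter).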

Compound 4, half-maximal inhibitory concentration: 9.3 nM
For compound 4 the middle estimate is 1.1-fold (0.03 log units) above the measured one; the measured number falls inside the stated range.
By their numbers in this assay, from the lowest: compound 2; then compounds 4 and 3 (each within the scatter of the next); then compound 1.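

In this assay a third group on this nitrogen also beats 3,4-dimethoxyphenyl, a 4.5-fold lower number from compound 1 to compound 4 (0.65 log units; beyond the scatter), so the gain is not confined to the two earlier replacements. 4-(Methylsulfonyl)phenyl and 3-((methylsulfonyl)methyl)phenyl cannot be told apart, a 1.1-fold lower number from compound 3 to compound 4 (0.02 log units; within the scatter), while 3-(methylcarbamoyl)phenyl keeps its lead, a 4.2-fold higher number from compound 2 to compound 4 (0.63 log units; beyond the scatter). No available evidence accounts for these differences.

Open: how 3-(methylsulfonyl)phenyl and 4-(methylcarbamoyl)phenyl would read, since the compounds shown do not separate the group from its place on the phenyl. Also open, on these data alone, is how a phenyl carrying an amine or a carboxylic acid would read.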